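Ester series on the shared core: compound 1 to compound 3

The source may hold more compounds than are shown below. What is called first, only, known or untested is meant among the compounds shown, and "the series" means these compounds.

Among the compounds with values here, compound 1 `O=C(CCCCCc1ccccc1)OCC1COCCOCCOCCOCCOCCO1` carries the only number in the set. In a functional assay on HBL-100 cells (Homo sapiens) for inhibition, read by sulforhodamine B assay, with a stated time of 48 h (on this read-out higher numbers stand for weaker inhibition of growth and lower numbers for stronger inhibition of growth), compound 1 gives 64000 nM. Compound 2 `O=C(CCCCC1CCCCC1)OCC1COCCOCCOCCOCCO1` returns a limit of the assay, > 100000 nM, in this assay. That limit is the limit of > 100000 nM in this assay, at which 1 of the 2 values shown sits. Compound 3 `CC(C)=CC1C(C(=O)OCC2COCCOCCOCCOCCOCCO2)C1(C)C` is not yet measured. It differs from compound 1 by 2,2-dimethyl-3-(2-methylprop-1-en-1-yl)cyclopropyl in place of 5-phenylpentyl on a carbonyl carbon. Within the data shown here, no measured step mirrors this change. A step within the scatter is expected, as a 1.1-fold higher number from compound 1 to compound 3 (0.04 log units; within the scatter) in this assay. Compound 3 is estimated at 70000 nM in this assay, with a range from 25000 nM to 150000 nM.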

Compound 3, concentration for 50% growth inhibition: 40000 nM
Compound 3: middle estimate off by 1.8-fold (0.24 log units), on the high side; the measured number falls inside the stated range.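

On a carbonyl carbon of the shared core, 2,2-dimethyl-3-(2-methylprop-1-en-1-yl)cyclopropyl in place of 5-phenylpentyl gives, in this assay, a 1.6-fold lower number from compound 1 to compound 3 (0.20 log units; within the scatter). This pair therefore shows that the six-membered aromatic ring of 5-phenylpentyl is not needed for a measured number at this place, and that this exchange moves the read-out no further than the scatter. Compound 2 alone remains a limit of the assay, not a number: the limit of > 100000 nM in this assay, at which 1 of the 3 values shown sits.

Open, going by these compounds, is whether any group here can move the number beyond the scatter. An amine, a carboxylic acid or a longer chain on this carbonyl carbon would test that.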